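The compounds below may be only part of what the source reports. "The series", "measured", "known", "first", "only" and "open" are said of these compounds alone.

- compound 1 `CCNC(=O)Nc1sc2ccccc2c1C(=O)N1CCN(C2CCN(C(=O)C(C)C)CC2)CC1`: "not determined" (no result reported)
- compound 2 `CCNC(=O)Nc1sc2ccccc2c1C(=O)N1CCN(C2CCN(C(=O)NC(C)(C)C)CC2)CC1`: 775 nM

Both compounds were tested in a functional assay on HepG2 cells (Homo sapiens) for inhibition, read by scintillation counting, with a stated time of 2 h; a lower number here means a stronger inhibitor, a higher number a weaker inhibitor. Among the measured compounds shown here, there, compound 2 gives 775 nM, the only number available, so it cannot yet be ranked against anything. Compound 3 `CCNC(=O)Nc1sc2ccccc2c1C(=O)N1CCN(C2CCN(C(=O)OC(C)(C)CF)CC2)CC1` keeps the shared core but loses the (tert-butyl)amino on the carbonyl carbon. In its place is a group of 6 heavy atoms with no ring: a group of 6 heavy atoms (4 carbon, 1 oxygen, 1 fluorine; no ring) in place of a group of 5 heavy atoms (4 carbon, 1 nitrogen; no ring), on a carbonyl carbon. For the measured compounds named here, no measured step bears on this change, so the expectation is loose: a modest move toward stronger inhibition in this assay. The estimated step is a 2.2-fold lower number from compound 2 to compound 3 (0.35 log units; beyond the scatter). For compound 3 the expected value is 350 nM, with an estimated range of 70 nM to 1700 nM.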

Compound 3, half-maximal inhibitory concentration: 61 nM
The estimate for compound 3 lay 5.7-fold (0.76 log units) above the measured number, and the stated range ends above it.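

In this assay, the group on this carbonyl carbon proves to have a large effect on the read-out: replacing the (tert-butyl)amino group with the oxygen- and fluorine-bearing group gives a 13-fold lower number from compound 2 to compound 3 (1.10 log units; beyond the scatter). This single step changes several atoms at once, so it cannot assign the gain to any one of them. Nothing available accounts for the gain. The compounds shown leave open whether the oxygen or the fluorine matters more. A tert-butoxy group, which has the oxygen but no fluorine, would separate the two.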